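Benzyl in place of furan-2-yl on a shared ester

This account rests on a few compounds, and the source may have more. Where it says the series, first, only, none or still open, it means among the compounds named here.

Compound 1 `C/C=C1/[C@H](O[C@@H]2O[C@H](CO)[C@@H](O)[C@H](O)[C@H]2O)OC=C(C(=O)OC)[C@H]1CC(=O)OCc1ccco1` – > 15000 nM
Compound 2 `C#CCOC(=O)C[C@@H]1C(C(=O)OC)=CO[C@@H](O[C@@H]2O[C@H](COC(C)=O)[C@@H](OC(C)=O)[C@H](OC(C)=O)[C@H]2OC(C)=O)/C1=C/C` – > 15000 nM
Compound 3 `C/C=C1/[C@H](O[C@@H]2O[C@H](COC(C)=O)[C@@H](OC(C)=O)[C@H](OC(C)=O)[C@H]2OC(C)=O)OC=C(C(=O)OC)[C@H]1CC(=O)OCCC(C)C` – > 15000 nM

In a functional assay on SK-BR-3 cells (Homo sapiens) for antiproliferative activity, read by MTT assay, with a stated time of 72 h (a higher number here means a weaker inhibitor, a lower number a stronger inhibitor), compound 1 gives > 15000 nM, which is a limit of the assay and not a number. Compound 2 likewise gives only a limit. Compound 3 gives only a limit as well. Within the data shown here, the single measured step, a step that the two limits leave unreadable from compound 2 to compound 3, therefore cannot be read, since (the limit of > 15000 nM in this assay, at which 3 of the 3 values shown sit). Compound 4 `C/C=C1/[C@H](O[C@@H]2O[C@H](CO)[C@@H](O)[C@H](O)[C@H]2O)OC=C(C(=O)OC)[C@H]1CC(=O)OCCc1ccccc1` differs from compound 1 by benzyl in place of furan-2-yl on a saturated chain carbon bound to an oxygen next to a carbonyl group. Among the measured compounds shown here, no measured step bears on this change, and compound 1 stands only at the limit. Compound 4 is expected to sit at the limit again, estimated at 20000 nM, between 8000 nM and 50000 nM. The expected step that the limit leaves unreadable from compound 1 to compound 4 is none beyond the scatter.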

Compound 4, half-maximal inhibitory concentration: 11000 nM
Compound 4: the middle estimate sits 1.8-fold (0.26 log units) above what was measured; low and high end bracket the measured number.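

Benzyl in place of furan-2-yl on a saturated chain carbon bound to an oxygen next to a carbonyl group gives the only value shown in this assay that is not a limit, so this position can yield a number: an at least 1.3-fold lower number from compound 1 to compound 4 (0.13 log units; that floor lies within the scatter). The true size of this step cannot be read, because compound 1 stands only at a limit: the limit of > 15000 nM in this assay, at which 3 of the 4 values shown sit.

As far as these compounds go, how an amine, a carboxylic acid or a longer chain in place of benzyl would read in this assay remains open.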